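The source may hold more compounds than are shown below. What is called first, only, known or untested is meant among the compounds shown, and "the series" means these compounds.

In a functional assay on PC-3 cells (Homo sapiens) for antiproliferative activity, read by MTT assay, with a stated time of 72 h (a lower number here means a stronger inhibitor, a higher number a weaker inhibitor), compound 1 `CCCCC(=O)c1ccc(C(CC)(CC)c2ccc(C#CC(O)(CC)CC)c(C)c2)n1CC` reaches only a limit of the assay, > 50000 nM. For the measured compounds named here, compound 2 `CCn1c(C(=O)N[C@H](C(=O)O)C(C)C)ccc1C(CC)(CC)c1ccc(C#CC(O)(CC)CC)c(C)c1` gives 5000 nM, the only actual number so far. Compound 3 `CCn1c(C(=O)NCCC(=O)O)ccc1C(CC)(CC)c1ccc(C#CC(O)(CC)CC)c(C)c1` has 2-carboxyethyl in place of 1-carboxy-2-methylpropyl on an amide-type nitrogen. Going by the values given here, one measured step bears on this change: an at least 10-fold lower number from compound 1 to compound 2 (1.00 log units; beyond the scatter), which lies beyond the scatter and put (1-carboxy-2-methylpropyl)amino in place of butyl on a carbonyl carbon. That step brought in a carboxy-bearing group, whereas the new change swaps one carboxy-bearing group for another. A jump of the size seen in an at least 10-fold lower number from compound 1 to compound 2 (1.00 log units; beyond the scatter) is therefore not expected here. The expected step, a 1.6-fold higher number from compound 2 to compound 3 (0.20 log units; within the scatter), stays within the scatter, and this one comparison cannot firmly set its direction. Compound 3 is estimated at 8000 nM, with an expected range from 2500 nM to 30000 nM.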

Compound 3, half-maximal inhibitory concentration: 5130 nM
Estimate against measurement, compound 3: 1.6-fold (0.19 log units) above; low and high end bracket the measured number.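

In this assay, a 1.0-fold higher number from compound 2 to compound 3 (0.01 log units; within the scatter), so on this amide-type nitrogen, 2-carboxyethyl and the larger 1-carboxy-2-methylpropyl, which carries a defined stereocentre, cannot be told apart. The gain over butyl on a carbonyl carbon now appears with a second carboxy-bearing group, as an at least 9.7-fold lower number from compound 1 to compound 3 (0.98 log units; beyond the scatter). The true size of that step stays unknown, because compound 1 gives only a limit, not a number: the limit of > 50000 nM in this assay, at which 1 of the 3 values shown sits.

The compounds shown leave open whether the carboxylic acid itself matters, since both groups on this nitrogen carry one and neither a methyl ester nor a plain ethyl group appears there. They also leave open how a longer chain before the carboxylic acid, or an amine in its place, would read in this assay.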